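The compounds below may be only part of what the source reports. "The series", "measured", "known", "first", "only" and "open" are said of these compounds alone.

Working notes on the series.

Compound 1 `O=S(=O)(Cc1ccccc1)N1CCC2(CC1)OOC1(CCCC1)OO2` and compound 2 `O=S(=O)(Cc1ccccc1)N1CCC2(CC1)OOC1(CCCCCC1)OO2` both carry benzyl on a sulfonyl sulfur; the difference between their two cores is not broken down here. Compound 3 `Cc1ccc(S(=O)(=O)N2CCC3(CC2)OOC2(CCCC2)OO3)cc1` keeps the core of compound 1 and has 4-methylphenyl in place of benzyl on a sulfonyl sulfur.

In a functional assay on Huh-7 cells (Homo sapiens) for cytotoxicity, read by MTT assay, with a stated time of 72 h (on this read-out higher numbers stand for lower toxicity in this test and lower numbers for higher toxicity in this test), compound 1 gives > 100 ug/mL, which is a limit of the assay and not a number. Compound 2 gives > 100 ug/mL in this assay, again a limit. Compound 3 gives > 100 ug/mL in this assay, also a limit. Accordingly a step that the two limits leave unreadable from compound 1 to compound 3.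

Compound 4 `Cc1ccc(S(=O)(=O)N2CCC3(CC2)OOC2(CCCCCC2)OO3)cc1` is not yet measured. It stands to compound 2 as compound 3 stands to compound 1: 4-methylphenyl in place of benzyl on a sulfonyl sulfur, the same change at the same place.

For compound 4 the expected step in this assay is a step that the limit leaves unreadable from compound 2 to compound 4, which beside the unreadable earlier step rests on (the limit of > 100 ug/mL in this assay, at which 3 of the 3 values shown sit). On that basis compound 4 is expected to give about 150 ug/mL in this assay, estimated between 60 ug/mL and 400 ug/mL, most likely reported as a limit once more.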

Compound 4, half-maximal cytotoxic concentration: > 100 ug/mL
Compound 4: no number, only a limit (the forecaster's own chance of this, stated with the estimate: 85%); the middle value lies beyond the limit too.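

The step from compound 2 to compound 4 cannot be read, as both compounds give only a limit and not a number in this assay: the limit of > 100 ug/mL in this assay, at which 4 of the 4 values shown sit.

The compounds shown leave open whether 4-methylphenyl in place of benzyl on a sulfonyl sulfur changes the read-out at all, and what the half-maximal cytotoxic concentration of any of the four compounds is.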